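The source may hold more compounds than are shown below. What is called first, only, known or untested is meant among the compounds shown, and "the series" means these compounds.

Measured so far in a functional assay on CCRF-CEM cells (Homo sapiens), with a stated time of 96 h; a higher number here means a weaker inhibitor, a lower number a stronger inhibitor:
compound 1 `CCCSC[C@H]1OC(n2cnc3c(N)ncnc32)[C@H](O)[C@@H]1O` gives 160000 nM
compound 2 `Nc1ncnc2c1ncn2C1O[C@H](CSCCO)[C@@H](O)[C@H]1O` gives 100000 nM

Compound 2 sits within the scatter of compound 1 on these numbers. Compound 3 `CCSC[C@H]1OC(n2cnc3c(N)ncnc32)[C@H](O)[C@@H]1O` is reached from compound 2 by one change, hydrogen in place of hydroxy on a saturated chain carbon, two bonds along the chain from a sulfur. Among the measured compounds shown here, the one measured step on that carbon is a 1.6-fold lower number from compound 1 to compound 2 (0.20 log units; within the scatter) and it lay within the scatter. No step beyond the scatter is therefore expected in this assay, and the estimated step is a 1.3-fold higher number from compound 2 to compound 3 (0.11 log units; within the scatter) in size. For compound 3 the estimate is 130000 nM and 60000 nM to 280000 nM is the expected range.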

Compound 3, half-maximal inhibitory concentration: 200000 nM
Compound 3: middle estimate off by 1.5-fold (0.19 log units), on the low side; measured number inside the range.
By their numbers in this assay, from the lowest: compounds 2, 1 and 3 (each within the scatter of the next).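

Hydrogen in place of hydroxy on this carbon (a 2.0-fold higher number from compound 2 to compound 3 (0.30 log units; within the scatter)) shows that in this assay the hydroxy group can be lost without a step beyond the scatter. Hydrogen in place of methyl at the same place (a 1.3-fold higher number from compound 1 to compound 3 (0.10 log units; within the scatter)) also stays within the scatter, so hydroxy, methyl and hydrogen are not separated here. No measurement on hand accounts for these numbers.

From the compounds shown here alone, whether an amine or a carboxylic acid on this carbon, or a longer chain on the sulfur, would give a step beyond the scatter remains open.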